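Aryl change on the ring nitrogen: compound 3 to compound 4

A few compounds are considered here, and "the series" means these few. Any claim that something is new, unique, unknown or untested is made for them only; others in the source may bear on it.

Measured in an assay on CHO cells for displacement of a labelled ligand from adenosine receptor A1 (Homo sapiens), read by scintillation counting, with a stated time of 120 min, tested at 10 uM; a higher number here means more inhibition at the concentration tested (going by the name of the read-out), a lower number less inhibition:
- compound 1 `Nc1scc(CN2CCN(c3ccc(F)cc3Cl)CC2)c1C(=O)c1ccc(Cl)cc1`: 0%
- compound 2 `Nc1scc(CN2CCN(c3ccccc3C(F)(F)F)CC2)c1C(=O)c1ccc(Cl)cc1`: 0%
- compound 3 `Nc1scc(CN2CCN(c3ccccc3F)CC2)c1C(=O)c1ccc(Cl)cc1`: 4%

Compound 3 sits within the scatter of both others: a number 4 percentage points higher from compound 1 to compound 3 (within the scatter) and a number 4 percentage points higher from compound 2 to compound 3 (within the scatter), so all three read near zero in this assay. Compound 4 `Nc1scc(CN2CCN(c3ccc(F)c(F)c3)CC2)c1C(=O)c1ccc(Cl)cc1` carries 3,4-difluorophenyl in place of 2-fluorophenyl on an amine nitrogen in a ring. Going by the values given here, the steps that bear on it are the earlier aryl swaps on the same ring nitrogen, no change at the digits printed from compound 1 to compound 2 (within the scatter) and a number 4 percentage points higher from compound 1 to compound 3 (within the scatter), none of which moved the read-out beyond the scatter. No step beyond the scatter is therefore expected for compound 4 in this assay. Compound 4 is expected to give 3%, within 0% to 15%. The expected step is a number 1 percentage points lower from compound 3 to compound 4 (within the scatter).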

Compound 4, a percentage reported as inhibition, at one concentration (the size of the read-out at that concentration, not a potency): 0%
The estimate for compound 4 lay 3 percentage points above the measured number; the range from low to high includes it.
By their numbers in this assay, from the lowest: compounds 1, 2, 4 and 3 (each within the scatter of the next).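

Within this assay the aryl group on the ring nitrogen now carries two fluorines and no substituent at the 2 position, unlike the 2-fluorophenyl, 2-(trifluoromethyl)phenyl and 2-chloro-4-fluorophenyl groups, yet the read-out stays near zero: a number 4 percentage points lower from compound 3 to compound 4 (within the scatter) and no change at the digits printed from compound 2 to compound 4 (within the scatter) and no change at the digits printed from compound 1 to compound 4 (within the scatter) are the steps. Across these four aryl groups, the halogen pattern therefore makes no difference beyond the scatter. No measurement available here explains this flat result.

Going by these compounds, whether a methoxy, an amine or a carboxylic acid on the phenyl ring would change the read-out remains open. So does whether any change elsewhere on the shared core would lift it beyond the scatter.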